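The source may report more compounds than this note shows. Statements on the series, on what has been measured and on what is new or still open speak of the compounds shown alone.

Three compounds of this series already carry numbers in an assay on CHO cells for inhibition of metabotropic glutamate receptor 1 (Rattus norvegicus); on this read-out lower numbers stand for stronger inhibition and higher numbers for weaker inhibition. Compound 1 `C=CCOC(=O)Cn1c(C)c(C(=O)OC(C)(C)C)c(C)c1C(=O)OCCC` gives 12600 nM; compound 2 `CCOC(=O)c1[nH]cc(C(=O)OC(C)(C)C)c1C` gives 340 nM; compound 3 `CCCOC(=O)c1[nH]c(C(=O)NCC2CC2)c(C(=O)OC(C)(C)C)c1C` gives 2500 nM. Among these, compound 2 stands at the lowest number, and its gaps to compound 3 and to compound 1 both lie beyond the usual scatter of repeated measurements. No pair of these compounds differs in a single place, so no clean single-change step is available.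

Compound 4 `Cc1c(C(=O)OC(C)(C)C)c[nH]c1C(=O)OCc1ccco1` has not yet been measured. It differs from compound 2 in one place: furan-2-yl in place of methyl on a saturated chain carbon bound to an oxygen next to a carbonyl group. In plain terms, the ethoxy group of compound 2 becomes a (furan-2-yl)methoxy group.

For the measured compounds named here, with no measured step of the same kind to lean on, the expectation for this change is cautious: a small step in this assay, likely toward a higher number, and possibly no more than the scatter itself. The expected step from compound 2 to compound 4 is a 1.8-fold higher number from compound 2 to compound 4 (0.25 log units; within the scatter). On that basis compound 4 is estimated at 600 nM, within a range of 150 nM to 2500 nM.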

Compound 4, half-maximal inhibitory concentration: 1200 nM
Compound 4: the middle estimate sits 2.0-fold (0.30 log units) below what was measured; low and high end bracket the measured number.
By their numbers in this assay, from the lowest: compound 2; then compound 4; then compound 3; then compound 1.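

In this assay, for the compounds shown here, this is the first clean single-change reading: on the saturated chain carbon bound to an oxygen next to a carbonyl group, furan-2-yl in place of methyl gives a 3.5-fold higher number from compound 2 to compound 4 (0.55 log units; beyond the scatter) and lies beyond the usual scatter. The step is modest, so this place accepts a much larger group with a five-membered aromatic ring and inhibition remains measurable, though weaker. Nothing available here accounts for why the number rises.

A single step cannot show whether the ring itself, its oxygen or simply the added size matters, so it sets no trend for this place. Going by these compounds, whether a phenyl ring or a longer chain such as butyl in the same place would give a similar step remains open.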